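The source may report more compounds than this note shows. Statements on the series, on what has been measured and on what is new or still open speak of the compounds shown alone.

The measured compounds are these. Compound 1 `O=C(NNc1cccc(Cl)c1)c1cccc(NS(=O)(=O)c2cnc(O)nc2O)c1` gives 11800 nM. Compound 2 `O=C(NNc1ccccc1F)c1cccc(NS(=O)(=O)c2cnc(O)nc2O)c1` reaches only the limit of the assay, > 20000 nM. Compound 3 `O=C(NNc1cccc(Cl)c1)c1ccccc1NS(=O)(=O)c1cnc(O)nc1O` gives 10800 nM.

All three were tested in a functional assay on SGC-7901 cells (Homo sapiens) for antiproliferative activity, read by MTT assay, with a stated time of 24 h; a lower number here means a stronger inhibitor, a higher number a weaker inhibitor. Compound 1 and compound 2 differ by one change, (2-fluorophenyl in place of 3-chlorophenyl on an amine nitrogen), and that change gave an at least 1.6-fold higher number from compound 1 to compound 2 (0.22 log units; that floor lies within the scatter). The size of this step is known only as a floor, since compound 2 sits at the limit of > 20000 nM in this assay, at which 1 of the 3 values shown sits. Compound 3 is built from the same atoms as compound 1, joined differently; the difference between the two cores is not broken down here. In this assay compound 3 and compound 1 lie within the usual scatter of each other, so the two numbers show no separation.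

Compound 4 `O=C(NNc1ccccc1F)c1ccccc1NS(=O)(=O)c1cnc(O)nc1O` has not yet been measured in this assay. It stands to compound 3 as compound 2 stands to compound 1: the change is 2-fluorophenyl in place of 3-chlorophenyl on an amine nitrogen, the same change at the same place. Among the compounds with values here, from the one measured example of it, from compound 1 to compound 2, a step of similar direction is expected here, namely a 2.0-fold higher number from compound 3 to compound 4 (0.31 log units; beyond the scatter). Compound 4 is therefore expected to give about 22000 nM in this assay. The expected range for compound 4 runs from 12000 nM to 45000 nM. Given that compound 2 reached only a limit, it is also quite possible that compound 4 will return a limit rather than a number.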

Compound 4, half-maximal inhibitory concentration: > 20000 nM
Compound 4 ended at the assay's limit; the forecaster's own chance of this, stated with the estimate: 55%; the middle value lies beyond the limit too.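

In this assay compound 4 gives > 20000 nM, which is a limit of the assay and not a number. Carried to the second core, 2-fluorophenyl in place of 3-chlorophenyl on the amine nitrogen gave an at least 1.8-fold higher number from compound 3 to compound 4 (0.26 log units; that floor lies within the scatter), so this step is known only as a floor, as it was on the core of compound 1. The two cores can therefore be set side by side only through these floors, which shows that the 2-fluorophenyl compound ended at the limit on both but does not show how large the change is on either core or whether the sizes match: the same change on two cores in this assay, an at least 1.6-fold higher number (0.22 log units; that floor lies within the scatter) from compound 1 to compound 2 and an at least 1.8-fold higher number (0.26 log units; that floor lies within the scatter) from compound 3 to compound 4; the limit leaves it open whether they differ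

The compounds shown leave open whether the step belongs to the exchange of chlorine for fluorine or to the different substitution of the phenyl ring, a question that a 2-chlorophenyl or a 3-fluorophenyl group on the same amine nitrogen could address. They also leave open how other groups at this place, such as an unsubstituted phenyl or a 3-methoxyphenyl, would read on either core.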